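This account rests on a few compounds, and the source may have more. Where it says the series, first, only, none or still open, it means among the compounds named here.

Of the compounds shown here, three have been read in a physicochemical assay for acid dissociation, read by capillary electrophoresis, tested at 100 uM. Compound 1 `CS(=O)(=O)NC(=O)CCc1ccccc1` gives 4.94, and compound 2 `O=S(=O)(Cc1ccccc1)c1ccccc1O` gives 7.12. Compound 3 `CC1=C(O)CC(Cc2ccccc2)C1=O`, at 4.47, has the lowest number of the three, and its gaps to both others lie beyond the scatter of repeated measurements. Compound 4 `O=C1C=C(O)CC1Cc1ccccc1` carries hydrogen in place of methyl on a double-bonded ring carbon. Within the data shown here, no measured pair shows this change, which leaves the expectation as a judgement: a small step in this assay towards a lower number, no larger than the usual scatter. The expected step is a number 0.27 log units lower from compound 3 to compound 4 (within the scatter). For compound 4 the estimate is 4.2, with an expected range from 3.8 to 4.6.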

Compound 4, acid dissociation constant: 4.01
Compound 4: the middle estimate sits 0.19 log units above what was measured; the measured number falls inside the stated range.
By their numbers in this assay, from the lowest: compound 4; then compound 3; then compound 1; then compound 2.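

In this assay, among these compounds, hydrogen in place of methyl on a double-bonded ring carbon gives a number 0.46 log units lower from compound 3 to compound 4 (beyond the scatter) and this is the first pair here that differs in only one place. It shows that this single change, next to the ring atom that bears a hydroxy group, shifts the read-out by more than the scatter. Nothing measured here explains the step. The compounds shown leave open how an ethyl group or a chlorine atom would read at this place. They also leave open whether the step would keep its size if an amine replaced the group of 7 heavy atoms.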